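The source may hold more compounds than are shown below. What is called first, only, known or untested is meant among the compounds shown, and "the series" means these compounds.

- Compound 1 `CCC(=O)NNC(=O)c1csc2ncc(-c3ccc(OC)cc3)n12` gives 53200 nM
- Compound 2 `CC(=O)NNC(=O)c1csc2ncc(-c3ccc(Br)cc3)n12` gives 1830 nM

Both values come from a functional assay on MCF7 cells (Homo sapiens) for antiproliferative activity, read by MTT assay, with a stated time of 72 h (a higher number here means a weaker inhibitor, a lower number a stronger inhibitor), and compound 2 holds the lower number of the two, with a gap to compound 1 that lies beyond the scatter. Compound 3 `CCC(=O)NNC(=O)c1csc2ncc(-c3ccc(Br)cc3)n12` follows from compound 2 by a single change of methyl in place of hydrogen on a saturated chain carbon bound to a carbonyl carbon so that acetyl becomes propanoyl. Among the measured compounds shown here, compound 1 also carries propanoyl, but it differs from compound 2 in more than one place, and no measured pair shows this change alone. In this assay the expected 1.4-fold higher number from compound 2 to compound 3 (0.15 log units; within the scatter) is a small rise in the number that may well stay within the scatter. Compound 3 is expected at 2600 nM with 800 nM to 9000 nM as the estimated range.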

Compound 3, half-maximal inhibitory concentration: 15000 nM
The estimate for compound 3 lay 5.8-fold (0.76 log units) below the measured number; the whole stated range lies below it.
By their numbers in this assay, from the lowest: compound 2; then compound 3; then compound 1.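

In this assay the methyl in place of hydrogen on a saturated chain carbon bound to a carbonyl carbon gives an 8.2-fold higher number from compound 2 to compound 3 (0.91 log units; beyond the scatter) and so shows, with nothing else changed, that this position is sensitive to the turn from acetyl to propanoyl. With propanoyl held in place, bromo in place of methoxy on an aromatic carbon gives a 3.5-fold lower number from compound 1 to compound 3 (0.55 log units; beyond the scatter) and thus counts as a separate effect on the number. No measurement offered here explains either step.

The compounds shown leave open whether the number would keep rising with a longer chain such as butanoyl, or what formyl or an amine at this place would give. They also leave open whether the acetyl and bromo steps would hold with methoxy on the core.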